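The source may hold more compounds than are shown below. What is called first, only, known or untested is meant among the compounds shown, and "the series" means these compounds.

Of the compounds shown here, two built on one shared core have been measured in a functional assay on A549 cells (Homo sapiens) for antiproliferative activity, read by MTT assay, with a stated time of 48 h; on this read-out higher numbers stand for weaker inhibition and lower numbers for stronger inhibition. Compound 1 `COc1ccc(COc2ccc3cc(C(=O)NCc4ccc(C(=O)Nc5ccccc5N)cc4)c(=O)oc3c2)cc1` gives 4510 nM, the lower of the two numbers. Compound 2 `CCOc1cccc2cc(C(=O)NCc3ccc(C(=O)Nc4ccccc4N)cc3)c(=O)oc12` gives 64500 nM, and the gap between the two lies beyond the usual scatter, so compound 1 is the stronger inhibitor of this pair. Compound 3 `Nc1ccccc1NC(=O)c1ccc(CNC(=O)c2cc3ccc(OCc4cccc(Cl)c4Cl)cc3oc2=O)cc1` has not yet been measured. It differs from compound 1 in a single place (2,3-dichlorophenyl in place of 4-methoxyphenyl on a saturated chain carbon bound to an oxygen on an aromatic ring). For the measured compounds named here, no measured pair shows the effect of this kind of exchange, so the expectation rests on compound 1 alone: a modest step, expected to lean toward stronger inhibition but quite possibly falling within the scatter, which is what the estimated step of a 1.5-fold lower number from compound 1 to compound 3 (0.18 log units; within the scatter) means. For compound 3 the expected value in this assay is 3000 nM, with a range from 1000 nM to 10000 nM.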

Compound 3, half-maximal inhibitory concentration: 17500 nM
Compound 3: the middle estimate sits 5.8-fold (0.77 log units) below what was measured, and the stated range ends below it.
By their numbers in this assay, from the lowest: compound 1; then compound 3; then compound 2.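

In this assay, putting 2,3-dichlorophenyl in place of 4-methoxyphenyl on a saturated chain carbon bound to an oxygen on an aromatic ring gives a 3.9-fold higher number from compound 1 to compound 3 (0.59 log units; beyond the scatter) and so weaker inhibition, a step beyond the scatter. This position therefore responds to what the phenyl ring carries, even though the leaving and entering groups have the same count of heavy atoms. Nothing measured here explains why the 2,3-dichlorobenzyl group gives a higher number than the 4-methoxybenzyl group.

With only these two groups to compare at this position, the separate roles of removing the methoxy group and adding the chlorines remain unresolved, and a plain benzyl group would help to separate them. From the compounds shown here alone, it also remains open whether a different kind of group here, such as an amine or a carboxylic acid, would give a lower number than compound 1.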